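The compounds below may be only part of what the source reports. "The series", "measured", "known", "first", "only" and "open" are said of these compounds alone.

Three analogues built on one shared core have been examined in an assay on isolated protein for inhibition of DNA topoisomerase 1 (Homo sapiens); a lower number here means a stronger inhibitor, a higher number a weaker inhibitor. Compound 1 `COc1cc(C(C)O)c(OC)c2c1C(=O)C=CC2=O` gives 111000 nM, compound 2 `CCCCCC(O)c1cc(OC)c2c(c1OC)C(=O)C=CC2=O` gives 39000 nM, and compound 3 `CCC(O)c1cc(OC)c2c(c1OC)C(=O)C=CC2=O` gives 122000 nM. On these numbers compound 3 stands highest, although its value and that of compound 1 lie within the scatter of one another, as a 1.1-fold higher number from compound 1 to compound 3 (0.04 log units; within the scatter) shows; only compound 2 is set apart from it, by a 3.1-fold higher number from compound 2 to compound 3 (0.50 log units; beyond the scatter).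

Compound 4 `CCCCCCC(O)c1cc(OC)c2c(c1OC)C(=O)C=CC2=O` differs from compound 3 by butyl in place of hydrogen on a saturated chain carbon, three bonds along the chain from an aromatic carbon and an oxygen on a saturated carbon. The closest parallel among the measured steps is a 2.8-fold lower number from compound 1 to compound 2 (0.45 log units; beyond the scatter), where the same butyl group enters two bonds along the chain from an aromatic carbon rather than three. The step of a 3.1-fold higher number from compound 2 to compound 3 (0.50 log units; beyond the scatter) removes propyl at the same place along the chain where butyl enters here and runs the other way. Both measured steps are modest, and nothing among the three compounds argues for a larger effect from a chain lengthened at this place. The expected step is therefore a 3.1-fold lower number from compound 3 to compound 4 (0.48 log units; beyond the scatter) in this assay, modest and downward. The estimate for compound 4 in this assay is 40000 nM, with a range from 18000 nM to 90000 nM.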

Compound 4, half-maximal inhibitory concentration: 30100 nM
Compound 4: the middle estimate sits 1.3-fold (0.12 log units) above what was measured, and the stated range covers the measured number.
By their numbers in this assay, from the lowest: compounds 4 and 2 (each within the scatter of the next); then compounds 1 and 3 (each within the scatter of the next).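

In this assay, butyl in place of hydrogen on a saturated chain carbon, three bonds along the chain from an aromatic carbon and an oxygen on a saturated carbon, gives a 4.1-fold lower number from compound 3 to compound 4 (0.61 log units; beyond the scatter), so a downward step of this size now appears at this place as well, and it matches the earlier step: the same change on two cores in this assay, a 2.8-fold lower number (0.45 log units; beyond the scatter) from compound 1 to compound 2 and a 4.1-fold lower number (0.61 log units; beyond the scatter) from compound 3 to compound 4, 1.4-fold (0.15 log units) apart, within the scatter of two such steps

A single methyl at the far end of the chain gives no readable change, as with a 1.3-fold lower number from compound 2 to compound 4 (0.11 log units; within the scatter), and the short chains behave the same way: the same change on two cores in this assay, a 1.1-fold higher number (0.04 log units; within the scatter) from compound 1 to compound 3 and a 1.3-fold lower number (0.11 log units; within the scatter) from compound 2 to compound 4, 1.4-fold (0.15 log units) apart, within the scatter of two such steps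

Pentyl in place of hydrogen gives a 3.7-fold lower number from compound 1 to compound 4 (0.57 log units; beyond the scatter), so the four compounds fall into two groups, compounds 1 and 3 with the short chains and compounds 2 and 4 with the long ones, and no step within either group can be read.

Going by these compounds, whether a chain longer than 1-hydroxyheptyl would lower the number further, or whether the values level off at this length, remains open. Also open, on these data alone, is how this assay would respond to an amine or a carboxylic acid at the end of the chain, or to a carbonyl in place of the hydroxyl.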